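Carbonyl substituent changes on the shared piperidine carbamate core

The compounds below may be only part of what the source reports. "The series", "measured", "known", "first", "only" and "open" are said of these compounds alone.

Measured so far:
compound 1 `Cc1nc(S(C)(=O)=O)ccc1Oc1ncnc(OC2CCN(C(=O)O[C@@H](C)CF)CC2)c1F`: 186 nM
compound 2 `Cc1nc(S(C)(=O)=O)ccc1Oc1ncnc(OC2CCN(C(=O)OC3(C(F)(F)F)COC3)CC2)c1F`: 29.3 nM
compound 3 `Cc1nc(S(C)(=O)=O)ccc1Oc1ncnc(OC2CCN(C(=O)SC(C)C)CC2)c1F`: 6.8 nM

In a functional assay on isolated protein for inhibition of Glucose-dependent insulinotropic receptor (Homo sapiens), read by HTRF and cAMP accumulation (on this read-out higher numbers stand for an effect only at larger amounts of compound and lower numbers for an effect already at smaller amounts), compound 3 stands lowest of the three numbers: a 4.3-fold lower number from compound 2 to compound 3 (0.63 log units; beyond the scatter), and a 27-fold lower number from compound 1 to compound 3 (1.44 log units; beyond the scatter). Compound 4 `Cc1nc(S(C)(=O)=O)ccc1Oc1ncnc(OC2CCN(C(=O)C(F)(F)F)CC2)c1F` carries trifluoromethyl in place of isopropylsulfanyl on a carbonyl carbon. Every measured step in this set is a change of the group on the carbonyl carbon, and each moved the number beyond the scatter: a 6.3-fold lower number from compound 1 to compound 2 (0.80 log units; beyond the scatter), a 4.3-fold lower number from compound 2 to compound 3 (0.63 log units; beyond the scatter). A change at this place is therefore expected to matter again. Among the measured compounds shown here, no measured compound carries a trifluoromethyl on the carbonyl carbon, so the direction cannot be read from the steps directly; a modest loss from compound 3 is estimated, an 8.8-fold higher number from compound 3 to compound 4 (0.95 log units; beyond the scatter). Compound 4 is expected at 60 nM, with a range from 15 nM to 250 nM.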

Compound 4, half-maximal effective concentration: 151 nM
For compound 4 the middle estimate is 2.5-fold (0.40 log units) below the measured one; measured number inside the range.
By their numbers in this assay, from the lowest: compound 3; then compound 2; then compounds 4 and 1 (each within the scatter of the next).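

In this assay, trifluoromethyl directly on the carbonyl carbon gives up most of what isopropylsulfanyl provides (a 22-fold higher number from compound 3 to compound 4 (1.35 log units; beyond the scatter)) and also falls short of the (3-(trifluoromethyl)oxetan-3-yl)oxy group (a 5.2-fold higher number from compound 2 to compound 4 (0.71 log units; beyond the scatter)). Compound 4 and compound 1 cannot be told apart (a 1.2-fold lower number from compound 1 to compound 4 (0.09 log units; within the scatter)), so two quite different groups on this carbon end up at the same level. Nothing available explains these differences.

On these data alone, an amine or a plain ethyl chain on the carbonyl carbon remains open. So does whether the isopropylsulfanyl result depends on the sulfur or on the isopropyl group.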